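The source may hold more compounds than are shown below. What is called first, only, known or untested is meant among the compounds shown, and "the series" means these compounds.

Of the compounds shown here, two have been measured in a functional assay on A549 cells (Homo sapiens) for antiproliferative activity, read by MTT assay, with a stated time of 72 h; a higher number here means a weaker inhibitor, a lower number a stronger inhibitor. Compound 1, with the structure `COc1cc2ncnc(Nc3ccc(OCc4cccc(F)c4)c(Cl)c3)c2cc1OCCCCC(=O)Nc1ccc(S(N)(=O)=O)cc1`, gives 7860 nM in this assay. Compound 2, with the structure `NS(=O)(=O)c1ccc(NC(=S)Nc2ccc3ncnc(Nc4cccc(C(F)(F)F)c4)c3c2)cc1`, gives 10100 nM in this assay. Of the two numbers, compound 2 has the higher one, but its gap to compound 1 lies within the scatter of repeated measurements, so the two are best read as about equally potent. Compounds 1 and 2 differ in several places at once, so the pair shows only that both sit in the same region of weak inhibition.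

Compound 3, with the structure `NS(=O)(=O)c1ccc(NC(=S)Nc2ccc3ncnc(Nc4cccc(F)c4)c3c2)cc1`, has not yet been measured. It differs from compound 2 in one place: fluoro in place of trifluoromethyl on an aromatic carbon. For the measured compounds named here, with no measured pair in this set that isolates this change, there is nothing to anchor the direction of the step. The expectation is a small step from compound 2 to compound 3, at most a modest weakening, likely no larger than the scatter, given as a 1.3-fold higher number from compound 2 to compound 3 (0.11 log units; within the scatter). On that basis compound 3 is estimated at 13000 nM in this assay, with a range from 4500 nM to 40000 nM.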

Compound 3, half-maximal inhibitory concentration: 25900 nM
The estimate for compound 3 lay 2.0-fold (0.30 log units) below the measured number; the measured number falls inside the stated range.
By their numbers in this assay, from the lowest: compounds 1 and 2 (each within the scatter of the next); then compound 3.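

Compounds 1 and 2 differ in several places at once, so they could not show what the group on this aromatic ring contributes, but compound 2 and compound 3 differ only there. Replacing 3-(trifluoromethyl)phenyl with 3-fluorophenyl gives a 2.6-fold higher number from compound 2 to compound 3 (0.41 log units; beyond the scatter) in this assay and so marks a weakening beyond the scatter, which shows that this position is not indifferent to the group it carries, even though the step is modest and both compounds remain weak inhibitors. Nothing measured in this set speaks to why the smaller fluoro, with 1 heavy atom against the 4 of trifluoromethyl, goes with the weaker number.

For the compounds shown here, with only two groups compared at this position, two points cannot show a trend, and a plain hydrogen, a methyl or a methoxy in the same place would be needed to tell whether trifluoromethyl is unusually favourable or fluoro unusually poor. Going by these compounds, whether the same swap would shift the number by a similar amount on a different core, such as that of compound 1, also remains open.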